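The source may hold more compounds than are shown below. What is called first, only, known or untested is meant among the compounds shown, and "the series" means these compounds.

For the measured compounds named here, in a functional assay on A549 cells (Homo sapiens) for inhibition, read by sulforhodamine B assay, with a stated time of 74 h (a higher number here means a weaker inhibitor, a lower number a stronger inhibitor), compound 1 (`Cc1ccc(S(=O)(=O)N2C(=O)COC23C=CC(=O)C=C3)cc1`) gives 110 nM, the only actual number in this small set. Compound 2 (`CS(=O)(=O)N1C(=O)COC12C=CC(=O)C=C2`) gives only a limit, > 10000 nM. Going by the values given here, the one measured step is an at least 90-fold higher number from compound 1 to compound 2 (1.95 log units; beyond the scatter), with methyl in place of 4-methylphenyl on a sulfonyl sulfur.

Compound 3 (`Cc1ccc(S(=O)(=O)N2C(=O)C(C)OC23C=CC(=O)C=C3)cc1`) keeps the 4-methylphenyl group of compound 1 and changes the core instead: methyl in place of hydrogen on a saturated ring carbon. This is methyl in place of hydrogen on a saturated ring carbon, next to the ring oxygen.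

The measured step shows that this assay can respond strongly to a change in this series, but it lies at the sulfonyl sulfur, not on the ring carbon, so it bears only indirectly. Among the compounds with values here, no measured step covers the new place. The expectation therefore starts from compound 1 at 110 nM and allows a small move towards a higher number, which may not pass the scatter. The estimate amounts to an expected 1.6-fold higher number from compound 1 to compound 3 (0.21 log units; within the scatter). Compound 3 is expected at 180 nM, with an estimated range from 60 nM to 600 nM.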

Compound 3, half-maximal inhibitory concentration: > 10000 nM
Compound 3 gave a limit, no number; the forecaster's own chance of this, stated with the estimate: 5%; middle value at least 55-fold (1.74 log units) away from the limit.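

In this assay, the saturated ring carbon next to the ring oxygen now emerges as a second sensitive place in the series, alongside the sulfonyl sulfur: methyl in place of hydrogen there gives an at least 90-fold higher number from compound 1 to compound 3 (1.95 log units; beyond the scatter). Compound 3 gives > 10000 nM, which is a limit of the assay and not a number. The addition of a single carbon on the core therefore goes as far as can be read here, and the change on the ring carbon and the change on the sulfonyl sulfur cannot be ranked against each other, since both end at the same limit: the limit of > 10000 nM in this assay, at which 2 of the 3 values shown sit.

From the compounds shown here alone, whether this ring carbon accepts anything other than hydrogen stays open, since a fluorine atom or a hydroxyl group there could still separate the effect of any substituent from that of methyl in particular. Also open, going by these compounds, is whether a 4-chlorophenyl or an unsubstituted phenyl group on the sulfonyl sulfur would hold the activity of compound 1, and whether such a group would change the response to methyl on the ring carbon.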